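The compounds below may be only part of what the source reports. "The series", "measured", "known", "first", "only" and "open" are said of these compounds alone.

Series notes. In a functional assay on HEK293 cells for agonist activity at lutropin-choriogonadotropic hormone receptor (Homo sapiens), read by cAMP accumulation (on this read-out higher numbers stand for larger maximal responses and lower numbers for smaller maximal responses), compound 1 `CSc1nc(-c2cccc(O)c2)c2c(N)c(C(=O)NC(C)(C)C)sc2n1` gives 63.9%, compound 2 `CSc1nc(-c2cccc(F)c2)c2c(N)c(C(=O)NC(C)(C)C)sc2n1` gives 51.1% and compound 3 `COc1cccc(-c2nc(SC)nc3sc(C(=O)NC(C)(C)C)c(N)c23)c1F` gives 46.3%. Compound 3 carries the lowest of the three numbers, but only the gap to compound 1 is real: a number 17.6 percentage points lower from compound 1 to compound 3 (beyond the scatter), whereas a number 4.8 percentage points lower from compound 2 to compound 3 (within the scatter). Compound 4 `COc1cccc(-c2nc(SC)nc3sc(C(=O)NC(C)(C)C)c(N)c23)c1OC` differs from compound 3 by methoxy in place of fluoro on an aromatic carbon. Going by the values given here, no measured step swaps fluoro for methoxy directly. The nearest guides are a number 12.8 percentage points lower from compound 1 to compound 2 (beyond the scatter), an oxygen-bearing group giving way to fluoro, and a number 4.8 percentage points lower from compound 2 to compound 3 (within the scatter), the step that brought in the methoxy group. For compound 4 the expected step is therefore a number 3.7 percentage points higher from compound 3 to compound 4 (within the scatter), small and within the scatter, leaning upward at most. For compound 4 the estimate in this assay is 50%, with an expected range of 35% to 65%.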

Compound 4, largest response reached (reported as efficacy), in percent of the reference or control that the assay uses: 50.1%
Compound 4: the middle estimate sits 0.1 percentage points below what was measured, and the stated range covers the measured number.
By their numbers in this assay, from the lowest: compounds 3, 4 and 2 (each within the scatter of the next); then compound 1.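

In this assay, methoxy in place of fluoro at this position, ortho to a large group and ortho to a methoxy group, gives a number 3.8 percentage points higher from compound 3 to compound 4 (within the scatter). Going by these compounds alone, this is the first direct exchange at this position, and it shows that adding a hydrogen-bond acceptor and one more heavy atom here does not separate the two compounds on maximal response. No evidence is available to explain this result. The compounds shown leave open whether an amine or an ethoxy group at this position would keep the response within the scatter of compound 3 and compound 4.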